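Dropping the Nitro Group from Compound 3: An Expectation

The source may report more compounds than this note shows. Statements on the series, on what has been measured and on what is new or still open speak of the compounds shown alone.

Compound 1 `Clc1ccc(-n2cc(CSc3nc4ccccc4s3)nn2)cc1`: 50%
Compound 2 `Fc1ccc(-n2cc(CSc3nc4ccccc4s3)nn2)cc1`: 77.8%
Compound 3 `O=[N+]([O-])c1ccc(-n2cc(CSc3nc4ccccc4s3)nn2)cc1`: 75%

Three compounds on a shared core were measured in a functional assay on the whole organism (strain Albino Wistar) for inhibition, with Rattus norvegicus as the target, read by paw edema, with stated times of 1 h and 3 h, at a dose of 10 mg/kg by the oral route; on this read-out higher numbers stand for more inhibition at the one dose given (going by the name of the read-out) and lower numbers for less inhibition. Compound 3 stands second highest of the three: its nearest neighbour is compound 2, a number 2.8 percentage points lower from compound 2 to compound 3 (within the scatter), and its furthest is compound 1, a number 25 percentage points higher from compound 1 to compound 3 (beyond the scatter). Compound 4 `c1ccc(-n2cc(CSc3nc4ccccc4s3)nn2)cc1` differs from compound 3 in one place: hydrogen in place of nitro on an aromatic carbon.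

Among the measured compounds shown here, no measured step exchanges a substituent for hydrogen, so none bears directly on this change. The steps that do touch the nitro group are a number 25 percentage points higher from compound 1 to compound 3 (beyond the scatter) and a number 2.8 percentage points lower from compound 2 to compound 3 (within the scatter); they show that the three substituted compounds span a modest range in this assay, with compound 1 lowest. For the measured compounds named here, compound 4, carrying no substituent at that place, has no direct precedent, and its value is expected to fall within the span of the measured compounds. Compound 4 is estimated at 60%, between 42% and 78%, which is expected to mean a number 15 percentage points lower from compound 3 to compound 4 (beyond the scatter).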

Compound 4, a percentage reported as inhibition, in the whole organism at one dose (the size of the read-out at that dose, not a potency): 46.7%
Compound 4: the middle estimate sits 13.3 percentage points above what was measured; low and high end bracket the measured number.
By their numbers in this assay, from the lowest: compounds 4 and 1 (each within the scatter of the next); then compounds 3 and 2 (each within the scatter of the next).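

Hydrogen at this place, on an aromatic carbon para to a large group, gives the series its unsubstituted reference in this assay. Exchanging nitro for hydrogen gives a number 28.3 percentage points lower from compound 3 to compound 4 (beyond the scatter) and exchanging fluoro for hydrogen gives a number 31.1 percentage points lower from compound 2 to compound 4 (beyond the scatter), so both groups stand clearly above hydrogen here, while chloro goes against any general gain from a substituent, with a number 3.3 percentage points lower from compound 1 to compound 4 (within the scatter) on exchange for hydrogen. Nothing available accounts for this split among the three groups.

Going by these compounds, whether the gain over hydrogen extends to other groups at this place, such as a methoxy group, an amine or a carboxylic acid, remains open. On these data alone, with a single oral dose behind each number, it is also open whether these steps would hold at other doses.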